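The source may report more compounds than this note shows. Statements on the series, on what has been measured and on what is new or still open speak of the compounds shown alone.

Measured compounds:
- compound 1 `CCC1C(=O)N(C)c2cnc(-n3ccc4cc(C(N)=O)ccc43)nc2N1c1ccn(C)n1`: 31300 nM
- compound 2 `CCC1C(=O)N(C)c2cnc(Nc3ccc(S(=O)(=O)NCCO)cc3)nc2N1c1ccn(C)n1`: "not active" (no number reported)

In a functional assay on K562 cells (Homo sapiens) for antiproliferative activity, read by CCK-8 assay, with a stated time of 72 h (on this read-out higher numbers stand for weaker inhibition of growth and lower numbers for stronger inhibition of growth), compound 1 gives 31300 nM, the only numerical result in this set. Compound 2, in this assay, is reported as "not active" (no number reported) with no number attached, so it offers no scale for comparison. Compound 1 therefore stands alone on the numbers shown; nothing places it as stronger or weaker than any other measured entry. Compound 3 `CCC1C(=O)N(C)c2cnc(-n3ccc4cc(C(=O)NC(C)C)ccc43)nc2N1c1ccn(C)n1` has not been measured. It differs from compound 1 by isopropyl in place of hydrogen on an amide-type nitrogen. Among the compounds with values here, no pair of measured compounds shows the effect of such a change, so the expectation for compound 3 rests only on the weak activity of compound 1. The step is expected to be small, a 1.3-fold lower number from compound 1 to compound 3 (0.10 log units; within the scatter), within or near the usual scatter. Compound 3 is estimated at 25000 nM, in a range from 6000 nM to 100000 nM.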

Compound 3, concentration for 50% growth inhibition: 8910 nM
Compound 3: middle estimate off by 2.8-fold (0.45 log units), on the high side; the range from low to high includes it.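

In this assay the carbamoyl group of compound 1 tolerates substitution on its nitrogen: isopropyl in place of the amide hydrogen gives a 3.5-fold lower number from compound 1 to compound 3 (0.55 log units; beyond the scatter), a modest step beyond the usual scatter. Within the data shown here, this is the first measured change at this position, and it shows that the amide hydrogen is not required for the growth inhibition seen here, with the number moving towards stronger inhibition. Nothing among the data presented explains this step.

On these data alone, it remains open whether another group on this nitrogen, such as a longer chain, a cyclopropyl ring or a chain ending in an amine, would lower the number further or raise it again. Compound 2, reported as not active, differs from compound 1 in more than one place and so says nothing about this change.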